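The source may hold more compounds than are shown below. What is called first, only, known or untested is meant among the compounds shown, and "the series" means these compounds.

Measured so far in an ADME assay on microsomes from liver (Mus musculus, strain CD-1) for metabolic stability, read by LC-MS, tested at 2 uM; a lower number here means that the compound disappears faster, a higher number that the compound lasts longer:
- compound 1 `Cn1cc(CNS(=O)(=O)c2ccccc2Nc2cc(-c3ccc4ccn(C)c4c3)c3nccnc3c2)cn1`: 0.267 h
- compound 2 `Cn1ccc2ccc(-c3cc(Nc4cnccc4C(=O)NCc4cncnc4)cc4nccnc34)cc21`: 0.4 h

Compound 2, at 0.4 h, stands within the scatter of compound 1, at 0.267 h, so these two numbers do not separate the compounds. Both half-lives are short on the scale of the read-out.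

The next compound to be read is compound 3 `Cn1cc(CNC(=O)c2ccncc2Nc2cc(-c3ccc4ccn(C)c4c3)c3nccnc3c2)cn1`, which differs from compound 2 in one place: 1-methyl-1H-pyrazol-4-yl in place of pyrimidin-5-yl on a saturated chain carbon bound to an amide-type nitrogen. Here 1-methyl-1H-pyrazol-4-yl stands in place of pyrimidin-5-yl on a saturated chain carbon bound to an amide-type nitrogen, and the ((pyrimidin-5-yl)methyl)carbamoyl group becomes ((1-methyl-1H-pyrazol-4-yl)methyl)carbamoyl.

For the measured compounds named here, the series holds no measured step between two compounds that differ in one place, so the size of this exchange in this assay has no direct precedent. Going by the values given here, the only anchor is compound 2 at 0.4 h, and no direction can be argued from the data. The expected change is therefore none beyond the scatter, and a 1.2-fold lower number from compound 2 to compound 3 (0.08 log units; within the scatter) is the estimated step. Compound 3 is expected at 0.33 h, with an estimated range of 0.15 h to 0.75 h.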

Compound 3, half-life: 0.267 h
For compound 3 the middle estimate is 1.2-fold (0.09 log units) above the measured one, within the range that was stated.
By their numbers in this assay, from the lowest: compounds 1, 3 and 2 (each within the scatter of the next).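

In this assay, for the compounds shown here, the exchange of pyrimidin-5-yl for 1-methyl-1H-pyrazol-4-yl on a saturated chain carbon bound to an amide-type nitrogen gives a 1.5-fold lower number from compound 2 to compound 3 (0.18 log units; within the scatter) and is the one step so far between compounds that differ in one place. At this position, a six-membered aromatic ring with 2 hetero atoms and a five-membered aromatic ring with 2 hetero atoms, both with 6 heavy atoms and the same counts of hydrogen-bond donors and acceptors, are therefore not separated by the half-life read-out. No measurement at hand offers an explanation for this result.

Still open, on these data alone, is whether any group at this place can shift the half-life beyond the scatter, for example an amine, a carboxylic acid or a longer alkyl chain in place of these two aromatic rings. Also open, as far as these compounds go, is whether the exchange from pyrimidin-5-yl to 1-methyl-1H-pyrazol-4-yl would read the same way on a different core, since this single pair gives no second case for comparison.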